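Swapping naphthalen-1-yl for 4-bromophenyl on the shared core

The compounds below may be only part of what the source reports. "The series", "measured", "known", "first", "only" and "open" are said of these compounds alone.

Going by the values given here, compound 2 `c1ccc2c(-c3cn4ccnc4c(-c4ccc5ncn(C6CCCCC6)c5c4)n3)cccc2c1` stands highest of the two numbers so far: in a functional assay on A498 cells (Homo sapiens) for inhibition, read by sulforhodamine B assay, with a stated time of 48 h, tested at 10 uM (on this read-out lower numbers stand for less inhibition and higher numbers for more inhibition at the one concentration tested (going by the name of the read-out)), compound 2 gives 14%, while compound 1 `COc1ccc(-c2cn3ccnc3c(-c3ccc4ncn(C5CCCCC5)c4c3)n2)cc1` gives -12.3%. Compound 3 `Brc1ccc(-c2cn3ccnc3c(-c3ccc4ncn(C5CCCCC5)c4c3)n2)cc1` differs from compound 2 in one place: 4-bromophenyl in place of naphthalen-1-yl on an aromatic carbon. Among the compounds with values here, the only step that bears on this change is a number 26.3 percentage points higher from compound 1 to compound 2 (beyond the scatter), where a single ring gave way to two fused rings. Compound 3 returns to a single ring, so a drop towards the level of compound 1 is expected, although the bromine is new and untested. Compound 3 is therefore estimated at 2%, between -14% and 18%, a step of a number 12 percentage points lower from compound 2 to compound 3 (beyond the scatter).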

Compound 3, a percentage reported as inhibition, at one concentration (the size of the read-out at that concentration, not a potency): 20.7%
Beside the measured number, compound 3's estimate is 18.7 percentage points below it; the measured number lies above the stated range.
By their numbers in this assay, from the lowest: compound 1; then compounds 2 and 3 (each within the scatter of the next).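

In this assay, a single ring at this position serves as well as two fused rings, since compound 2 and compound 3 cannot be told apart (a number 6.7 percentage points higher from compound 2 to compound 3 (within the scatter)). On the single ring, bromo in place of methoxy carries the larger difference (a number 33 percentage points higher from compound 1 to compound 3 (beyond the scatter)), so the ring count alone does not set the number. Nothing available explains either step. The compounds shown leave open whether a 4-chlorophenyl group would track the 4-bromophenyl of compound 3, and how an amine or a carboxylic acid on that ring would read.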